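Swapping a Benzyl Substituent in an Antiproliferative Series

This account rests on a few compounds, and the source may have more. Where it says the series, first, only, none or still open, it means among the compounds named here.

Measured compounds:
- compound 1, `CN(Cc1cccc(Br)c1)C(=O)c1cc2c(Cc3ccccc3)n[nH]c2cc1O`: 7100 nM in a functional assay on A2780 cells (Homo sapiens) for antiproliferative activity, read by resazurin assay, with a stated time of 72 h; a higher number here means a weaker inhibitor, a lower number a stronger inhibitor
- compound 2, `Cc1cccc(CN(C)C(=O)c2cc3c(Cc4ccccc4)n[nH]c3cc2O)c1`: "not determined" (no result reported) in this assay
- compound 3, `CN(Cc1ccc(F)cc1)C(=O)c1cc2c(Cc3ccccc3)n[nH]c2cc1O`: not yet measured

Only compound 1 carries a number in this assay, and it is a weak one. Compound 2, which bears a 3-methylbenzyl group in place of the 3-bromobenzyl of compound 1, has no value at all in this assay, so its standing cannot be placed on the numbers shown; it is known only as a structure.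

The step from compound 2 to compound 3 is a single change: 4-fluorophenyl in place of 3-methylphenyl on a saturated chain carbon bound to an amide-type nitrogen. Among the compounds with values here, because compound 2 has no measurement, no counted step can be given, and the expectation for compound 3 has to lean on what compound 1 shows.

Compound 3 is expected to behave as a weak inhibitor in this assay, within the scatter of compound 1, because compound 1 gives 7100 nM. Compound 3 is estimated at 8000 nM, with a range from 2500 nM to 25000 nM, and the possibility that only a limit is reported is real.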

Compound 3, half-maximal inhibitory concentration: 4100 nM
Compound 3: the middle estimate sits 2.0-fold (0.29 log units) above what was measured, within the range that was stated.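

In this assay the replacement of 3-bromophenyl by 4-fluorophenyl, on a saturated chain carbon bound to an amide-type nitrogen, gives a 1.7-fold lower number from compound 1 to compound 3 (0.24 log units; within the scatter) and so does not separate the two groups: the second number adds a second substituted phenyl at this position, and the two values cannot be told apart. The change swaps one halogen for another and alters the number in the group's name, yet this single pair shows no effect of the change beyond the usual scatter, and the step from compound 2 to compound 3 cannot be read, so the 3-methylbenzyl group cannot be set against either halogen-bearing benzyl group. Nothing measured here bears on why these two compounds read alike.

What the compounds shown leave open is whether any group at this position would move the number beyond the scatter, for instance a phenyl carrying an amine or a carboxylic acid, or a longer chain in place of the benzyl group. They also leave open whether 3-fluorophenyl or 4-bromophenyl would read like compound 1 and compound 3, which would separate the halogen from the number in its name.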